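The compounds below may be only part of what the source reports. "The series", "measured", "known", "first", "only" and "open" are said of these compounds alone.

In an ADME assay on HEK293 cells (Homo sapiens) for cytotoxicity, read by reporter gene assay and resazurin assay, with a stated time of 48 h (a higher number here means that more compound is tolerated, a lower number that less compound is tolerated), three compounds have been measured. Compound 1 `COc1c(Br)cccc1C(=O)Nc1ccc(Sc2nc3ccccc3s2)cc1` gives > 100000 nM, which is a limit of the assay rather than a number. Compound 2 `O=C(Nc1ccc(Sc2nc3ccccc3s2)cc1)c1cccc(Br)c1O` gives 71000 nM, and compound 3 `O=C(Nc1cccc(Cl)c1)c1cccc(Br)c1O` gives 32000 nM, the lowest of the two numbers. The change from compound 2 to compound 1 is methyl in place of hydrogen on an oxygen on an aromatic ring, and it brought an at least 1.4-fold higher number from compound 2 to compound 1 (0.14 log units; that floor lies within the scatter); this step carries only a floor because compound 1 sits at the limit of > 100000 nM in this assay, at which 1 of the 3 values shown sits. How the core of compound 3 differs from that of compound 2 is not broken down here.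

Compound 4 `COc1c(Br)cccc1C(=O)Nc1cccc(Cl)c1` has not yet been measured in this assay. It differs from compound 3 by methyl in place of hydrogen on an oxygen on an aromatic ring, the same change that was made from compound 2 to compound 1. Compound 4 is therefore expected to give 55000 nM, with a range from 25000 nM to 100000 nM. That estimate means an expected step of a 1.7-fold higher number from compound 3 to compound 4 (0.24 log units; within the scatter), which rests on the measured step of an at least 1.4-fold higher number from compound 2 to compound 1 (0.14 log units; that floor lies within the scatter) being at least as large as its floor, while the floor itself lies within the usual scatter.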

Compound 4, half-maximal cytotoxic concentration: > 100000 nM
Compound 4: only a limit was reported; the forecaster's own chance of this, stated with the estimate: 20%; at least 1.8-fold (0.25 log units) between middle value and limit.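

In this assay compound 4 gives > 100000 nM, which is a limit of the assay and not a number. The change from hydroxy to methoxy brings an at least 3.1-fold higher number from compound 3 to compound 4 (0.49 log units; beyond the scatter), so on this core the higher number lies beyond the scatter, whereas on the core of compound 1 the floor of the same change lies within it. This shows that the change raised the number by a clear margin on one core and did not lower it on the other, but it does not show that the change has the same size on both, since each step is only a floor: the same change on two cores in this assay, an at least 1.4-fold higher number (0.14 log units; that floor lies within the scatter) from compound 2 to compound 1 and an at least 3.1-fold higher number (0.49 log units; beyond the scatter) from compound 3 to compound 4; the limit leaves it open whether they differ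

The compounds shown leave open whether an ethyl group or a longer chain on that oxygen would also give a higher number than the hydroxy compounds, since methyl is the only group placed there. Any such comparison would meet the same ceiling that already holds half of the readings: the limit of > 100000 nM in this assay, at which 2 of the 4 values shown sit.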